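From Compound 1 to Compound 3: One Group Exchanged

The source may report more compounds than this note shows. Statements on the series, on what has been measured and on what is new or still open speak of the compounds shown alone.

In a physicochemical assay for solubility, in phosphate buffer, measured as kinetic solubility, at pH 6.5 (on this read-out higher numbers stand for higher solubility and lower numbers for lower solubility), compound 1 `COc1cc(C2=NN(c3ccc(C#N)c(Cl)c3)[C@@H](C3CCCC3)C2)ccc1C(=O)O` gives 271000 nM and compound 2 `CCOc1cc(C2=NN(c3ccc(C#N)c(C)c3)[C@@H](C3CCCC3)C2)ccc1C(=O)O` gives 193000 nM (two numbers within the usual scatter of repeated measurements). Compound 3 `COc1cc(C2=NN(c3ccc(C#N)c(C)n3)[C@@H](C3CCCC3)C2)ccc1C(=O)O` keeps the core of compound 1 but carries 5-cyano-6-methylpyridin-2-yl in place of 3-chloro-4-cyanophenyl on an amine nitrogen in a ring. Going by the values given here, no pair of measured compounds shows this exchange on its own, so no step beyond the scatter is expected in this assay in either direction, and the estimated step is small (a 1.0-fold lower number from compound 1 to compound 3 (0.02 log units; within the scatter)). The estimated value for compound 3 is 260000 nM (expected range 120000 nM to 520000 nM).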

Compound 3, solubility: 308000 nM
Estimate against measurement, compound 3: 1.2-fold (0.07 log units) below, within the range that was stated.
By their numbers in this assay, from the lowest: compounds 2, 1 and 3 (each within the scatter of the next).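

Placing 5-cyano-6-methylpyridin-2-yl instead of 3-chloro-4-cyanophenyl on the amine nitrogen in a ring gives the first reading of this exchange in this assay: a 1.1-fold higher number from compound 1 to compound 3 (0.06 log units; within the scatter). A ring with 1 hetero atom can therefore stand at this place without a step beyond the scatter, at least in this pair. No measurement here explains this result. On these data alone, it remains open whether a phenyl ring bearing an amine or a carboxylic acid at this place would also stay within the scatter.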